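Working notes: chloro to trifluoromethyl on compound 2

The compounds below may be only part of what the source reports. "The series", "measured", "known", "first", "only" and "open" are said of these compounds alone.

Measured so far in an ADME assay on microsomes from liver (Homo sapiens) for metabolic stability; on this read-out higher numbers stand for fast clearance and lower numbers for slow clearance:
- compound 1 `Cc1csc(C(=O)N[C@H]2CN(S(=O)(=O)c3ccccc3)C[C@@H]2C(=O)N[C@H]2CCCNC2)n1`: 9.1 mL.min-1.g-1
- compound 2 `Cc1oc(-c2ccc(Cl)cc2)nc1C(=O)N[C@H]1CN(S(=O)(=O)c2ccccc2)C[C@@H]1C(=O)N[C@H]1CCCNC1`: 4.9 mL.min-1.g-1

Compound 2, at 4.9 mL.min-1.g-1, lies within the usual scatter of compound 1, at 9.1 mL.min-1.g-1, so these two values cannot be told apart in this assay. Neither compound can be ranked on these numbers.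

The next compound is compound 3 `Cc1oc(-c2ccc(C(F)(F)F)cc2)nc1C(=O)N[C@H]1CN(S(=O)(=O)c2ccccc2)C[C@@H]1C(=O)N[C@H]1CCCNC1`. It carries trifluoromethyl in place of chloro on an aromatic carbon of the six-membered aromatic ring of carbon only, para to a large group: trifluoromethyl in place of chloro on an aromatic carbon. The rest of the structure is that of compound 2.

For the measured compounds named here, no step in one place between measured compounds is available, so nothing measured so far tests this change directly. The expectation therefore rests on compound 2 at 4.9 mL.min-1.g-1, with no step beyond the scatter expected in this assay. The expected change is a 1.1-fold higher number from compound 2 to compound 3 (0.05 log units; within the scatter). Going by the values given here, the range is kept wide, since only two values are known. For compound 3 the estimated value is 5.5 mL.min-1.g-1, with an expected range from 2.6 mL.min-1.g-1 to 11 mL.min-1.g-1.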

Compound 3, intrinsic clearance in microsomes: < 3 mL.min-1.g-1
Compound 3 was reported as a limit; the forecaster's own chance of this, stated with the estimate: 5%; middle value at least 1.8-fold (0.26 log units) from the limit.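

In this assay, compound 3 is reported as a limit, < 3 mL.min-1.g-1, and not as a number. Trifluoromethyl in place of chloro gives the first step in one place in this series, an at least 1.6-fold lower number from compound 2 to compound 3 (0.21 log units; that floor lies within the scatter), so this aromatic carbon carries the larger group, with 4 heavy atoms instead of 1, and no higher number appears. The floor of that step lies within the scatter, and its full size cannot be read because compound 3 sits at the limit of the read-out: the limit of < 3 mL.min-1.g-1 in this assay, at which 1 of the 3 values shown sits.

The compounds shown leave open how a nitrile, a methoxy group or plain hydrogen on this same aromatic carbon would read in this assay, and any such value could be set against compound 2 as a number but against compound 3 only as a limit. Compound 1 differs from compound 2 in more than one place, so it offers no test of the 4-chlorophenyl group, and whether the step goes beyond the scatter remains unsettled.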